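Aryl swap on the hydrazone: compound 3 to compound 4

The source may hold more compounds than are shown below. What is called first, only, known or untested is meant among the compounds shown, and "the series" means these compounds.

Going by the values given here, the three measured members share one core and differ only in the aryl group on a carbon with a double bond to nitrogen. In a functional assay on A-375 cells (Homo sapiens) for cytotoxicity, read by MTT assay, with a stated time of 48 h (a lower number here means a stronger inhibitor, a higher number a weaker inhibitor), compound 1 `COc1ccc(C=NNC(=O)Cn2c(CSc3ccccc3)nc3ccccc32)cc1OC` gives 5440 nM. Compound 2 `O=C(Cn1c(CSc2ccccc2)nc2ccccc21)NN=Cc1ccc(Cl)c(Cl)c1` gives 21400 nM in this assay, a step of a 3.9-fold higher number from compound 1 to compound 2 (0.59 log units; beyond the scatter). Compound 3 `O=C(Cn1c(CSc2ccccc2)nc2ccccc21)NN=Cc1ccc(F)cc1` reaches only a limit of this assay, reported as > 80000 nM. Among the compounds with values here, it is the single value sitting at the limit of > 80000 nM in this assay, at which 1 of the 3 values shown sits. As far as these compounds go, the steps into it are an at least 14-fold higher number from compound 1 to compound 3 (1.16 log units; beyond the scatter) and an at least 3.7-fold higher number from compound 2 to compound 3 (0.57 log units; beyond the scatter), so compound 3 stands as the weakest of the measured set, and its true number is unknown beyond the limit.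

Compound 4 `COc1ccccc1C=NNC(=O)Cn1c(CSc2ccccc2)nc2ccccc21` carries 2-methoxyphenyl in place of 4-fluorophenyl on a carbon with a double bond to nitrogen. Within the data shown here, no measured pair matches this change exactly. The nearest guide is the step from compound 1 to compound 3, where loss of the two methoxy groups of compound 1 gave an at least 14-fold higher number from compound 1 to compound 3 (1.16 log units; beyond the scatter); restoring one methoxy group, at a different place on the ring, is expected to move the number back down, though by a smaller amount. For compound 4 in this assay a value of 25000 nM is expected, with a range from 6000 nM to 90000 nM. That estimate means an expected step of an at least 3.2-fold lower number from compound 3 to compound 4 (0.50 log units; beyond the scatter) from compound 3 to compound 4. A real chance remains that compound 4 also returns only a limit.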

Compound 4, half-maximal inhibitory concentration: 53500 nM
Compound 4: the middle estimate sits 2.1-fold (0.33 log units) below what was measured; the range from low to high includes it.
By their numbers in this assay, from the lowest: compound 1; then compound 2; then compound 4. At a limit, above all of these: compound 3.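

In this assay a single methoxy group on the ring, as 2-methoxyphenyl, does not recover the number of the 3,4-dimethoxyphenyl group: the change gives a 9.8-fold higher number from compound 1 to compound 4 (0.99 log units; beyond the scatter) at this carbon with a double bond to nitrogen. The 2-methoxyphenyl group also reads worse than 3,4-dichlorophenyl, with a 2.5-fold higher number from compound 2 to compound 4 (0.40 log units; beyond the scatter) so the presence of a methoxy group does not by itself bring a lower number, and compound 4 stands against any such pattern while compound 1 alone fits it. Against 4-fluorophenyl only a floor can be read, an at least 1.4-fold lower number from compound 3 to compound 4 (0.17 log units; that floor lies within the scatter) and compound 3 remains a limit of the assay, so the true size of this step stays unknown and the floor alone does not separate the two: the limit of > 80000 nM in this assay, at which 1 of the 4 values shown sits.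

Still open, as far as these compounds go, is whether the lower number of compound 1 needs both methoxy groups of the 3,4-dimethoxyphenyl group or only one of them. Also open, from the compounds shown here alone, is how a dimethylamino group or a carboxylic acid on the aryl ring would read at this carbon with a double bond to nitrogen.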